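The source may hold more compounds than are shown below. What is called first, only, known or untested is meant among the compounds shown, and "the series" means these compounds.

Going by the values given here, in a functional assay on V79-379A cells (Cricetulus griseus) for cytotoxicity, read by MTT assay, in the presence of a further agent that is not named here (on this read-out higher numbers stand for weaker inhibition and lower numbers for stronger inhibition), compound 3 `CCOC(=S)Sc1c2c(n(C)c1C)C(=O)C=C(OC)C2=O` gives 67000 nM, the lowest of the three numbers measured so far and the strongest inhibition of the three. Compound 1 `COC1=CC(=O)c2c(c(COC(=O)c3ccccc3F)c(C)n2C)C1=O` gives 164000 nM and compound 2 `COC1=CC(=O)c2c(c(COCc3ccccc3)c(C)n2C)C1=O` gives 225000 nM, and each of these lies beyond the usual scatter from compound 3. All three values are high on this scale, so the inhibition is weak throughout.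

Compound 4 `COC1=CC(=O)c2c(c(COC(N)=O)c(C)n2C)C1=O` keeps the shared core but, on an aromatic carbon, swaps the group of compound 3 for (carbamoyloxy)methyl (a group of 5 heavy atoms (2 carbon, 1 nitrogen, 2 oxygen; no ring) in place of a group of 6 heavy atoms (3 carbon, 1 oxygen, 2 sulfur; no ring), on an aromatic carbon). Among the compounds with values here, no two measured compounds differ in one place alone, so no direct step is available as a guide. The new group looks more like the side chain of compound 1 at 164000 nM than like the group it replaces. A modest expected move toward a higher number, meaning weaker inhibition and lying slightly beyond the scatter, is therefore estimated as the step of a 2.2-fold higher number from compound 3 to compound 4 (0.35 log units; beyond the scatter) in this assay. For compound 4 the expected value is 150000 nM, with an estimated range from 50000 nM to 350000 nM.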

Compound 4, half-maximal inhibitory concentration: 25000 nM
Beside the measured number, compound 4's estimate is 6.0-fold (0.78 log units) above it; measured number outside the range, below it.
By their numbers in this assay, from the lowest: compound 4; then compound 3; then compounds 1 and 2 (each within the scatter of the next).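

In this assay, the side chain ending in a small amino group gives a lower number than either ring-bearing end: carbamoyl in place of benzyl on the oxygen gives a 9.0-fold lower number from compound 2 to compound 4 (0.95 log units; beyond the scatter), and amino in place of 2-fluorophenyl on the carbonyl carbon gives a 6.6-fold lower number from compound 1 to compound 4 (0.82 log units; beyond the scatter). Replacing the sulfur-containing group on the aromatic carbon with (carbamoyloxy)methyl also lowers the number, giving a 2.7-fold lower number from compound 3 to compound 4 (0.43 log units; beyond the scatter), so this position responds to what is placed there, and a group with a hydrogen-bond donor can sit there with no loss of inhibition. Nothing available here explains why these changes lower the number.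

On these data alone, it remains open whether the amino group itself is what counts, a question that a methylamino or dimethylamino group on the same carbonyl carbon would address. As far as these compounds go, it is also open how a plain hydroxymethyl group on the aromatic carbon would compare with compound 4.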